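Unsaturation Enters the Fatty Amide Chain

The compounds below may be only part of what the source reports. "The series", "measured", "known", "first", "only" and "open" are said of these compounds alone.

Of the compounds shown here, two built on a shared core have been tested in a functional assay on MCF7 cells (Homo sapiens) for antiproliferative activity, read by MTT assay, with a stated time of 48 h; a lower number here means a stronger inhibitor, a higher number a weaker inhibitor. Compound 1 `COc1cc(CNC(=O)CCCCCCC(C)C)ccc1OCCCCOc1ccc(C(N)=S)cc1` carries a saturated branched chain on its amide, and in this assay compound 1 gives 4990 nM. Compound 2 `COc1cc(CNC(=O)CCCCCCC(C)C)ccc1OC(=O)c1ccc(C(N)=S)cc1` is the second one tested; in this assay compound 2 reaches only a limit, > 50000 nM, so no number is known for it. Among the results shown, compound 1 therefore holds the only measured value, the other being a limit (the limit of > 50000 nM in this assay, at which 1 of the 2 values shown sits).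

Compound 3 `COc1cc(CNC(=O)CCCC/C=C/C(C)C)ccc1OCCCCOc1ccc(C(N)=S)cc1` keeps the core of compound 1 and differs from it in one place: 3-methylbut-1-en-1-yl in place of isopentyl on a saturated chain carbon, four bonds along the chain from a carbonyl carbon. The chain keeps its length and its branching and gains one double bond, sitting on a saturated chain carbon, four bonds along the chain from a carbonyl carbon. Going by the values given here, no pair of measured compounds differs by a change of this kind, so no measured step guides the expectation. Such a small alteration is expected to move the result in this assay little, if at all, beyond the usual scatter, and the estimated step is a 1.1-fold lower number from compound 1 to compound 3 (0.04 log units; within the scatter). Compound 3 is thus expected to give 4500 nM, with a likely range from 1500 nM to 13000 nM.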

Compound 3, half-maximal inhibitory concentration: 49800 nM
Compound 3: the middle estimate sits 11-fold (1.04 log units) below what was measured; the whole stated range lies below it.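

The opening pair could say nothing about the fatty chain, since compound 1 and compound 2 carry the same one. Going by these compounds alone, compound 3 gives the first reading of that chain: in this assay, one double bond brings a 10-fold higher number from compound 1 to compound 3 (1.00 log units; beyond the scatter). The swap of isopentyl for 3-methylbut-1-en-1-yl keeps the count of heavy atoms, adds no ring and no hydrogen-bond donor or acceptor, and the chain keeps its branch, yet the step lies beyond the usual scatter, so this place, on a saturated chain carbon, four bonds along the chain from a carbonyl carbon, does respond to a change this small.

Going by these compounds, whether the weaker result follows from the double bond itself or from where it stands stays open, as does the way a longer chain, a shorter chain or a carboxylic acid at the chain end would read out on the core of compound 1. The other side of the picture is also thin, as compound 2 remains a limit and not a number: the limit of > 50000 nM in this assay, at which 1 of the 3 values shown sits.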